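The source may report more compounds than this note shows. Statements on the series, on what has been measured and on what is new or still open speak of the compounds shown alone.

Compound 3, with the structure `N=c1sc2cc(OC(F)(F)F)ccc2n1CCS(=O)(=O)O`, stands at the edge of what a functional assay on the whole organism with Rattus norvegicus as the target (a higher number here means that more compound is needed for the effect, a lower number that less compound is needed), reports: in this assay compound 3 gives only the limit > 10 mg/kg, not a number. The two measured neighbours do give numbers. Compound 1, `CCCn1c(=N)sc2cc(OC(F)(F)F)ccc21`, gives 4.5 mg/kg in this assay, and compound 2, `N#CCn1c(=N)sc2cc(OC(F)(F)F)ccc21`, gives 3.5 mg/kg. The step from compound 1 to compound 2 is a 1.3-fold lower number from compound 1 to compound 2 (0.11 log units; within the scatter). Within the data shown here, the steps that lead into compound 3 both go the other way: an at least 2.2-fold higher number from compound 1 to compound 3 (0.34 log units; beyond the scatter) and an at least 2.8-fold higher number from compound 2 to compound 3 (0.45 log units; beyond the scatter), so the sulfo group on the chain is the one change here that pushes the number beyond the scatter, and pushes it up, with the limit of > 10 mg/kg in this assay, at which 1 of the 3 values shown sits, marking where compound 3 sits.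

Compound 4, `C[S+]([O-])CCCn1c(=N)sc2cc(OC(F)(F)F)ccc21`, undoes that change: a group of 4 heavy atoms (2 carbon, 1 oxygen, 1 sulfur; no ring) in place of a group of 4 heavy atoms (3 oxygen, 1 sulfur; no ring), on a saturated chain carbon, two bonds along the chain from an aromatic nitrogen. Since the sulfo group alone accounts for the rise seen in an at least 2.2-fold higher number from compound 1 to compound 3 (0.34 log units; beyond the scatter), removing it is expected to bring the number back toward compound 1 and compound 2. Compound 4 is therefore expected to give about 5 mg/kg in this assay, between 2 mg/kg and 15 mg/kg, a step of an at least 2.0-fold lower number from compound 3 to compound 4 (0.30 log units; that floor lies within the scatter) that is expected to leave the limit behind.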

Compound 4, dose for half-maximal effect: 2.3 mg/kg
Estimate against measurement, compound 4: 2.2-fold (0.34 log units) above; the range from low to high includes it.
By their numbers in this assay, from the lowest: compounds 4, 2 and 1 (each within the scatter of the next). At a limit, above all of these: compound 3.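

In this assay, the chain position is not closed to a sulfur-bearing group: the group of 4 heavy atoms that replaces sulfo gives an at least 4.3-fold lower number from compound 3 to compound 4 (0.63 log units; beyond the scatter), so the rise seen at compound 3 goes with the sulfo group, not with any group of that heavy-atom count at this place. Against the other two neighbours, compound 4 shows no change beyond the scatter, with a 1.5-fold lower number from compound 2 to compound 4 (0.18 log units; within the scatter) and a 2.0-fold lower number from compound 1 to compound 4 (0.29 log units; within the scatter), so the added sulfur and oxygen leave the number where the simpler chain ends put it. The step out of compound 3 gives only a floor, for its starting value is a limit of the assay and not a number: the limit of > 10 mg/kg in this assay, at which 1 of the 4 values shown sits.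

On these data alone, whether a carboxylic acid or an amine at the end of the chain would raise the number as the sulfo group does stays open. So does how a longer chain carrying the sulfo group would read.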